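A few compounds are considered here, and "the series" means these few. Any claim that something is new, unique, unknown or untested is made for them only; others in the source may bear on it.

Measured compounds in a functional assay on MCF7 cells (Homo sapiens) for cytotoxicity, read by sulforhodamine B assay, with a stated time of 48 h, tested at 0.1 uM; a higher number here means a weaker effect of the compound at the concentration tested, a lower number a stronger effect:
- compound 1, `COc1ccc(C(=O)/C=C/c2cc(-c3cc(OC)c(OC)c(OC)c3)n[nH]2)cc1OC`: 91%
- compound 2, `COc1ccc(C(=O)/C=C/c2cc(-c3cc(OC)c(OC)c(OC)c3)n[nH]2)cc1`: 93%
- compound 3, `COc1cc(-c2cc(/C=C/C(=O)c3ccc(F)c(F)c3)[nH]n2)cc(OC)c1OC`: 98%

Compound 1 holds the lowest of the three numbers in this assay, but the gaps to the other two are small: a number 2 percentage points higher from compound 1 to compound 2 (within the scatter) and a number 7 percentage points higher from compound 1 to compound 3 (within the scatter). The remaining pair is likewise close, a number 5 percentage points higher from compound 2 to compound 3 (within the scatter). None of the three compounds can be told apart on these numbers.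

Compound 4, `COc1cc(C(=O)/C=C/c2cc(-c3cc(OC)c(OC)c(OC)c3)n[nH]2)cc(OC)c1OC`, has not been measured yet. Compared with compound 1 it carries methoxy in place of hydrogen on an aromatic carbon. Going by the values given here, the only measured step that touches this kind of change is the one in which a methoxy was taken away, a number 2 percentage points higher from compound 1 to compound 2 (within the scatter), which stayed within the scatter; the two steps that swapped the group on the carbonyl carbon also stayed within the scatter. Among the compounds with values here, nothing measured so far suggests that adding one more methoxy should move the number beyond the scatter, so for compound 4 in this assay a value of about 90% is expected, within a range of 80% to 100%. The step this estimate implies is a number 1 percentage points lower from compound 1 to compound 4 (within the scatter), expected to be no larger than the scatter.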

Compound 4, a percentage reported as activity, at one concentration (the size of the read-out at that concentration, not a potency): 95%
Beside the measured number, compound 4's estimate is 5 percentage points below it; the measured number falls inside the stated range.
By their numbers in this assay, from the lowest: compounds 1, 2, 4 and 3 (each within the scatter of the next).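

In this assay, a further methoxy on an aromatic carbon, ortho to a methoxy group and meta to a large group, gives a number 4 percentage points higher from compound 1 to compound 4 (within the scatter). Going by these compounds alone, the earlier compounds showed only the removal of a methoxy from another carbon of this ring, so this is the first sign that adding one here also leaves the number within the scatter at this single concentration. No measurement at hand explains this result.

The compounds shown leave open whether a different kind of group at this position, such as an amine, a carboxylic acid or a longer chain, would move the number beyond the scatter. They also leave open whether methoxy and hydrogen could be told apart here at any other concentration.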